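Benzyl ether variants of a fluorinated amino acid core

The source may report more compounds than this note shows. Statements on the series, on what has been measured and on what is new or still open speak of the compounds shown alone.

Measured compounds, with their values in an assay on CHO cells for binding affinity to metabotropic glutamate receptor 2 (Rattus norvegicus); a lower number here means a stronger inhibitor, a higher number a weaker inhibitor:
compound 1 `N[C@]1(C(=O)O)[C@H]2[C@@H](C[C@H]1OCc1ccccc1)[C@]2(F)C(=O)O`: 7.14 nM
compound 2 `N[C@]1(C(=O)O)[C@H]2[C@@H](C[C@H]1OCc1cccc(Br)c1)[C@]2(F)C(=O)O`: 4.71 nM
compound 3 `N[C@]1(C(=O)O)[C@H]2[C@@H](C[C@H]1OCc1cccc(C(F)(F)F)c1)[C@]2(F)C(=O)O`: 5.72 nM

Compound 3 holds the second highest of the three numbers. Its nearest neighbour is compound 2, see a 1.2-fold higher number from compound 2 to compound 3 (0.08 log units; within the scatter), and its furthest is compound 1, see a 1.2-fold lower number from compound 1 to compound 3 (0.10 log units; within the scatter); both steps sit within the scatter, so the three compounds are not separated.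

Compound 4 `N[C@]1(C(=O)O)[C@H]2[C@@H](C[C@H]1OCc1cccc(-c3ccccc3)c1)[C@]2(F)C(=O)O` is not yet measured. It differs from compound 3 by phenyl in place of trifluoromethyl on an aromatic carbon.

Going by the values given here, the steps that bear on this place are a 1.5-fold lower number from compound 1 to compound 2 (0.18 log units; within the scatter) and a 1.2-fold lower number from compound 1 to compound 3 (0.10 log units; within the scatter), plus a 1.2-fold higher number from compound 2 to compound 3 (0.08 log units; within the scatter): each exchange at this aromatic carbon left the number within the scatter. Among the compounds with values here, no measured step covers a phenyl group here, so the expectation rests on the three exchanges alone. For compound 4 no step beyond the scatter is expected in this assay, and the estimate is 5.5 nM with a range of 2 nM to 15 nM. The expected step from compound 3 is a 1.0-fold lower number from compound 3 to compound 4 (0.02 log units; within the scatter).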

Compound 4, inhibition constant: 9.34 nM
Compound 4: middle estimate off by 1.7-fold (0.23 log units), on the low side; the measured number falls inside the stated range.
By their numbers in this assay, from the lowest: compounds 2, 3, 1 and 4 (each within the scatter of the next).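

In this assay, this aromatic carbon of the benzyl ether now carries a second six-membered aromatic ring, and the number stays within the scatter of all three earlier compounds (a 1.6-fold higher number from compound 3 to compound 4 (0.21 log units; within the scatter)) and (a 2.0-fold higher number from compound 2 to compound 4 (0.30 log units; within the scatter)) and (a 1.3-fold higher number from compound 1 to compound 4 (0.12 log units; within the scatter)). The earlier exchanges covered only bromo and trifluoromethyl; with phenyl, 6 heavy atoms enter where 4 leave, and the four compounds still are not separated. No measurement at hand accounts for this result.

The compounds shown leave open how an amine or a carboxylic acid at this aromatic carbon would read in this assay. They also leave open whether phenyl would stay within the scatter on another carbon of the ring, or with a longer chain in place of the benzyl ether link.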